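From benzyl to hydrogen on an oxygen

This account rests on a few compounds, and the source may have more. Where it says the series, first, only, none or still open, it means among the compounds named here.

Of the compounds shown here, two with a shared core have been tested in an ADME assay on BaF3 cells (Mus musculus) for cytotoxicity, read by MTT assay, with a stated time of 48 h (on this read-out lower numbers stand for stronger inhibition of growth and higher numbers for weaker inhibition of growth), and neither gave a number. Compound 1 `CC(C)n1nc(-c2ccon2)c2c(N)ncnc21` reads > 10000 nM as a limit of the assay. Compound 2 `CC(C)n1nc(/C=N/OCc2ccccc2)c2c(N)ncnc21` reads > 10000 nM as a limit too. Compound 2 thus stands with compound 1 at the limit of > 10000 nM in this assay, at which 2 of the 2 values shown sit, and has no number of its own.

Compound 3 `CC(C)n1nc(/C=N/O)c2c(N)ncnc21` has not yet been measured. It differs from compound 2 in one place, with hydrogen in place of benzyl on an oxygen. The one six-membered aromatic ring of carbon only leaves with the benzyl.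

For the measured compounds named here, no measured step shows what such a change does in this assay and no step beyond the scatter is expected there, in either direction. Compound 1 carries no benzyl and its value of > 10000 nM is also a limit, so losing that group is not expected to bring out growth inhibition. The expected step of a number no higher from compound 2 to compound 3 (the limit leaves the size open) is estimated to lie within the scatter. Compound 3 is estimated at 10000 nM with an expected range from 5000 nM to 20000 nM and the assay may well report only a limit.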

Compound 3, concentration for 50% growth inhibition: > 10000 nM
Compound 3: only a limit was reported; the forecaster's own chance of this, stated with the estimate: 80%; the middle value sits exactly at the limit.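

In this assay, for the compounds shown here, compound 3 gives only a limit, as compound 1 and compound 2 do, so no step from compound 1 or compound 2 to compound 3 can be read: the limit of > 10000 nM in this assay, at which 3 of the 3 values shown sit. The compounds shown leave open at what concentration any of the three would inhibit growth, and how their values would compare.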